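The source may report more compounds than this note shows. Statements on the series, on what has been measured and on what is new or still open speak of the compounds shown alone.

Three compounds share a core in which a sulfonamide nitrogen is joined through a six-carbon chain to an amine bearing a bromobenzyl group, and differ only in the aryl group on the sulfonyl sulfur. In a functional assay on MIA PaCa-2 cells (Homo sapiens) for inhibition, read by MTT assay, with a stated time of 72 h (on this read-out lower numbers stand for stronger inhibition of growth and higher numbers for weaker inhibition of growth), compound 1 `O=S(=O)(NCCCCCCNCc1ccc(Br)cc1)c1ccc(C(F)(F)F)cc1` gives 3830 nM, compound 2 `O=S(=O)(NCCCCCCNCc1ccc(Br)cc1)c1c(Cl)cccc1Cl` gives 14700 nM, and compound 3 `Cc1ccc(C)c(S(=O)(=O)NCCCCCCNCc2ccc(Br)cc2)c1` gives 12000 nM. Compound 3 thus sits with the second highest number of the three, close to compound 2 and well apart from compound 1. Among the compounds with values here, the only single-point step among them, a 1.2-fold lower number from compound 2 to compound 3 (0.09 log units; within the scatter), is within the scatter, so the exchange of one doubly substituted phenyl for another left the read-out essentially unchanged.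

Compound 4 `O=S(=O)(NCCCCCCNCc1ccc(Br)cc1)c1ccc(Cl)cc1` differs from compound 3 by 4-chlorophenyl in place of 2,5-dimethylphenyl on a sulfonyl sulfur. The step from compound 2 to compound 3 bears on it only loosely, since it compares two doubly substituted rings. The values of compound 1 and compound 3 show that a phenyl carrying a single trifluoromethyl group gives a markedly lower number than the 2,5-dimethylphenyl, and the 4-chlorophenyl of compound 4 resembles that singly substituted ring. Compound 4 is therefore expected to give a lower number than compound 3, with an estimated step of a 2.4-fold lower number from compound 3 to compound 4 (0.38 log units; beyond the scatter). The estimate for compound 4 in this assay is 5000 nM, within a range of 2000 nM to 13000 nM.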

Compound 4, concentration for 50% growth inhibition: 5900 nM
Compound 4: middle estimate off by 1.2-fold (0.07 log units), on the low side, within the range that was stated.
By their numbers in this assay, from the lowest: compounds 1 and 4 (each within the scatter of the next); then compounds 3 and 2 (each within the scatter of the next).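

In this assay the 4-chlorophenyl on the sulfonyl sulfur stands apart from both doubly substituted rings, with a 2.0-fold lower number from compound 3 to compound 4 (0.31 log units; beyond the scatter) against the 2,5-dimethylphenyl and a 2.5-fold lower number from compound 2 to compound 4 (0.40 log units; beyond the scatter) against the 2,6-dichlorophenyl, both modest steps; compound 2 carries chlorine too and stays within the scatter of compound 3, so the presence of chlorine alone does not go with the lower number. Chloro in place of trifluoromethyl on the aromatic carbon brings a 1.5-fold higher number from compound 1 to compound 4 (0.19 log units; within the scatter) and so no separation, which places the two singly substituted rings of compound 1 and compound 4 together and apart from the doubly substituted rings of compound 2 and compound 3. Nothing shown offers a measured reason for these differences.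

These four rings cannot tell whether the number of substituents or the places they occupy is what counts, and an unsubstituted phenyl, or a phenyl carrying a methoxy group or a nitrile, would test that reading. From the compounds shown here alone, whether the same grouping holds with a pyridine ring on the sulfonyl sulfur, or with a shorter or longer chain in the shared core, also stays open.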